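The compounds below may be only part of what the source reports. "The series", "measured", "known", "first", "only" and "open" are said of these compounds alone.

The shared core of this series is that of compound 1, `COc1ccc([C@H]2CC(=O)N(c3ccccc3)C2)cc1OC1CCCC1`. In a functional assay on HEK293 cells (Homo sapiens) for cytotoxicity (a higher number here means that more compound is tolerated, a lower number that less compound is tolerated), compound 1 gives > 10000 nM, which is a limit of the assay rather than a number. Compound 2, `COc1ccc([C@H]2CC(=O)N(c3cc(N)cc(N)c3)C2)cc1OC1CCCC1`, carries a 3,5-diaminophenyl in place of phenyl on an amide-type nitrogen in a ring. In this assay compound 2 gives > 10000 nM, again a limit. Compound 3, `COc1ccc([C@H]2CC(=O)N(c3ccncc3)C2)cc1OC1CCCC1`, carries pyridin-4-yl in place of phenyl on that same amide-type nitrogen. In this assay compound 3 gives > 10000 nM, also a limit. Because all three values sit at the limit of > 10000 nM in this assay, at which 3 of the 3 values shown sit, the steps a step that the two limits leave unreadable from compound 1 to compound 2, a step that the two limits leave unreadable from compound 1 to compound 3 and a step that the two limits leave unreadable from compound 2 to compound 3 cannot be read, so compound 1 stands at the limit together with the other two, with no ranking among them.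

Compound 4, `COc1ccc([C@H]2CC(=O)N(c3cccc(NCCCc4ccccc4)c3)C2)cc1OC1CCCC1`, differs from compound 1 as follows: (3-phenylpropyl)amino in place of hydrogen on an aromatic carbon. Among the measured compounds shown here, none of the measured steps touches this part of the molecule, and none of them has a readable size, so they give no guidance on how this assay will respond to this change. The expectation is that compound 4 remains near the limit, and the step of a number no higher from compound 1 to compound 4 (the limit leaves the size open) is expected to stay within the usual scatter. The estimated value for compound 4 is 10000 nM, between 3000 nM and 30000 nM.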

Compound 4, half-maximal cytotoxic concentration: > 10000 nM
Compound 4 gave a limit, no number (the forecaster's own chance of this, stated with the estimate: 60%); the middle value sits exactly at the limit.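

In this assay compound 4 gives > 10000 nM, which is a limit of the assay and not a number. Among the compounds shown here, the change from compound 1 to compound 4 therefore has no readable size, and no compound ranks ahead of another: the limit of > 10000 nM in this assay, at which 4 of the 4 values shown sit. The compounds shown leave open at what concentration any of them harms these cells, and whether (3-phenylpropyl)amino changes that concentration.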